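Methyl on the Amide Nitrogen: From Compound 3 to Compound 4

The source may report more compounds than this note shows. Statements on the series, on what has been measured and on what is new or still open speak of the compounds shown alone.

Compound 1, `CN1C/C(=C\c2ccccc2)C(=O)[C@]2(C1)[C@@H](c1ccccc1)CN(C)[C@@]21C(=O)N(C)c2ccccc21`: 70.7%
Compound 2, `CN1C/C(=C\c2ccc(Br)cc2)C(=O)[C@]2(C1)[C@@H](c1ccc(Br)cc1)CN(C)[C@@]21C(=O)N(C)c2ccccc21`: 49.1%
Compound 3, `CN1C/C(=C\c2ccc(Cl)cc2)C(=O)[C@]2(C1)[C@@H](c1ccc(Cl)cc1)CN(C)[C@@]21C(=O)Nc2ccccc21`: 63%

Of the compounds shown here, three have been measured in a functional assay on the whole organism (strain Wister albino) for inhibition, with Rattus norvegicus as the target, read by paw edema, with stated times of 1 h and 2 h, at a dose of 50 mg/kg by the intraperitoneal route; on this read-out higher numbers stand for more inhibition at the one dose given (going by the name of the read-out) and lower numbers for less inhibition. In this assay compound 3 gives 63%, the second highest of the three numbers. Its nearest neighbour is compound 1, whose number is higher by an amount within the scatter, so no order between those two can be stated. Compound 2 lies lower by an amount beyond the scatter. For the measured compounds named here, compound 1 and compound 2 each differ from compound 3 in more than one place, so no single step between measured compounds is available.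

Going by the values given here, compound 4, `CN1C/C(=C\c2ccc(Cl)cc2)C(=O)[C@]2(C1)[C@@H](c1ccc(Cl)cc1)CN(C)[C@@]21C(=O)N(C)c2ccccc21`, is the one unmeasured compound. It differs from compound 3 by methyl in place of hydrogen on an amide-type nitrogen in a ring. Among the compounds with values here, nothing among the measured compounds isolates this change: compound 1 and compound 2 both carry a methyl on that nitrogen but differ from compound 3 elsewhere as well, and their numbers fall on either side of it. The step in this assay is therefore expected to be small, with no direction that can be called beyond the scatter. Compound 4 is estimated at 60%, within a range from 45% to 75%. The expected step is a number 3 percentage points lower from compound 3 to compound 4 (within the scatter).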

Compound 4, a percentage reported as inhibition, in the whole organism at one dose (the size of the read-out at that dose, not a potency): 62.2%
Compound 4: the middle estimate sits 2.2 percentage points below what was measured, and the stated range covers the measured number.
By their numbers in this assay, from the lowest: compound 2; then compounds 4, 3 and 1 (each within the scatter of the next).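

In this assay, the change of methyl in place of hydrogen on an amide-type nitrogen in a ring can now be read on its own, and it gives a number 0.8 percentage points lower from compound 3 to compound 4 (within the scatter). With everything else in the structure held the same, the amide hydrogen can therefore give way to methyl at this position with no step beyond the scatter in this read-out, something compound 1 and compound 2 could not show, as each also differs from compound 3 elsewhere. No measurement of any property of these compounds bears on this result.

The compounds shown leave open whether a larger group on the same nitrogen, such as a longer alkyl chain, a benzyl group or a chain ending in a carboxylic acid, would also leave the number within the scatter. They also leave open whether the same small step would appear on a compound with other substituents on its two aryl rings, since this single pair carries only one such pattern.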